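Resolving the stereocentre of an inactive racemate

A few compounds are considered here, and "the series" means these few. Any claim that something is new, unique, unknown or untested is made for them only; others in the source may bear on it.

For the measured compounds named here, compound 1 `O=C([C@H]1Cc2cc(Cl)cc(-c3ccnc4ccsc34)c2O1)N1CCNCC1` is the first of two measured points. In an assay on Sf21 cells for inhibition of ubiquitin carboxyl-terminal hydrolase 1 (Homo sapiens), read by fluorescence (a higher number here means a weaker inhibitor, a lower number a stronger inhibitor), compound 1 gives only a limit, > 40000 nM, as noted in the limit of > 40000 nM in this assay, at which 1 of the 2 values shown sits. Compound 2 `O=C(C1Cc2cc(Cl)cc(-c3ccnc4[nH]ccc34)c2O1)N1CCNCC1` is the other point. In this assay compound 2 also gives only a limit, > 80000 nM, as noted in the limit of > 80000 nM in this assay, at which 1 of the 2 values shown sits. Compound 3 `O=C([C@H]1Cc2cc(Cl)cc(-c3ccnc4[nH]ccc34)c2O1)N1CCNCC1` differs from compound 2 in one stereo element: the two compounds have the same atoms and bonds; at least one stereo element is drawn with a configuration in one of them and without one in the other: 1 of 1 stereo elements differ; a stereocentre at a saturated ring carbon is drawn without a configuration in compound 2 and R in compound 3. Going by the values given here, no step between two measured compounds is available. With compound 2 at a limit, the expected step of a number no higher from compound 2 to compound 3 (the limit leaves the size open) is none beyond the scatter. Compound 3 is estimated at 80000 nM in this assay, with a range from 30000 nM to 200000 nM.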

Compound 3, half-maximal inhibitory concentration: > 80000 nM
Compound 3 was reported as a limit; the forecaster's own chance of this, stated with the estimate: 85%; the middle value lies on the limit itself.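

For the compounds shown here, compound 3 reads > 80000 nM, a limit of the assay, so no step to compound 1 or compound 2 can be read. The compounds shown leave open whether the drawn configuration or the exchanged aromatic group affects inhibition at all.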